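The source may hold more compounds than are shown below. What is called first, only, known or untested is meant among the compounds shown, and "the series" means these compounds.

Compound 1 `O=C(COc1ccc(C(=O)/C=C/c2ccc(F)c(F)c2)cc1)N[C@H]1CCOC1=O` is measured in a functional assay on MGC-803 cells (Homo sapiens) for antiproliferative activity, read by MTT assay, with a stated time of 72 h; on this read-out higher numbers stand for weaker inhibition and lower numbers for stronger inhibition. In this assay compound 1 reaches only the limit > 64000 nM. Compound 2 `CC(C)c1ccc(/C=C/C(=O)c2ccc(OCC(=O)N[C@H]3CCOC3=O)cc2)cc1` is the second member; in this assay compound 2 gives 16800 nM.

Compound 2 thus holds the only number shown in this assay, the one further value being a limit. Among the measured compounds shown here, the single measured step, an at least 3.8-fold lower number from compound 1 to compound 2 (0.58 log units; beyond the scatter), is itself known only as a bound, since its starting point is the limit (the limit of > 64000 nM in this assay, at which 1 of the 2 values shown sits). Compound 3 `O=C(COc1ccc(C(=O)/C=C/c2cccc([N+](=O)[O-])c2)cc1)N[C@H]1CCOC1=O` differs from compound 2 by 3-nitrophenyl in place of 4-isopropylphenyl on a double-bonded chain carbon bound to a double-bonded chain carbon. For the measured compounds named here, the one measured step bears on it in that both changes exchange the aryl group on the same chain carbon: compound 1 with 3,4-difluorophenyl gave only a limit, compound 2 with 4-isopropylphenyl a number. Compound 3 carries a third aryl group for which no direct comparison exists, so the expectation rests on the possibility that it behaves more like compound 1 than compound 2. For compound 3 a higher number than compound 2 is expected, by about a 2.4-fold higher number from compound 2 to compound 3 (0.38 log units; beyond the scatter). The estimate for compound 3 is 40000 nM, within a range of 14000 nM to 110000 nM, with a real chance that only a limit is reported.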

Compound 3, half-maximal inhibitory concentration: > 64000 nM
Compound 3 ended at the assay's limit (the forecaster's own chance of this, stated with the estimate: 35%); middle value at least 1.6-fold (0.20 log units) from the limit.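

In this assay, placing 3-nitrophenyl in place of 4-isopropylphenyl on a double-bonded chain carbon bound to a double-bonded chain carbon gives an at least 3.8-fold higher number from compound 2 to compound 3 (0.58 log units; beyond the scatter), so the loss seen at this position is not confined to the 3,4-difluorophenyl group. Among the compounds shown here, two different aryl groups, 3,4-difluorophenyl in compound 1 and 3-nitrophenyl in compound 3, now end at the same limit, leaving compound 2 as the only member of the series with a number: the limit of > 64000 nM in this assay, at which 2 of the 3 values shown sit. The step between compound 1 and compound 3 cannot be read, and these two aryl groups therefore cannot be ranked against each other.

The compounds shown leave open whether the number of compound 2 is tied to the isopropyl group itself or would also be reached with another carbon-only substituent, such as a tert-butyl group in 4-tert-butylphenyl, or with a plain phenyl group at this chain carbon. They also leave open whether an amine or a methoxy group on the aryl ring would keep a measurable number in this assay or end at the limit, as the nitro and difluoro groups did.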